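Amide variation on a shared chlorinated biaryl core

The compounds below may be only part of what the source reports. "The series", "measured", "known", "first", "only" and "open" are said of these compounds alone.

Measured compounds:
compound 1 `Cc1nc(C(=O)Nc2ccc(Cl)c(-c3nnc4c(Cl)cccn34)c2)cs1`: in a functional assay on T47D cells (Homo sapiens) for antiproliferative activity, read by MTT assay, with a stated time of 72 h (a lower number here means a stronger inhibitor, a higher number a weaker inhibitor), compound 1 gives > 100000 nM, a limit of the assay.
compound 2 `O=C(Nc1ccc(Cl)c(-c2nnc3c(Cl)cccn23)c1)c1cccnc1`: in this assay compound 2 gives > 100000 nM, a limit of the assay.
compound 3 `O=C(Nc1ccc(Cl)c(-c2nnc3c(Cl)cccn23)c1)c1cccc(Cl)c1`: in this assay compound 3 gives 30200 nM.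

Among the compounds with values here, compound 3 holds the only numerical value in the set; the other two sit at the limit of > 100000 nM in this assay, at which 2 of the 3 values shown sit. Compound 4 `O=C(Nc1ccc(Cl)c(-c2nnc3c(Cl)cccn23)c1)c1cccnc1Cl` carries 2-chloropyridin-3-yl in place of 3-chlorophenyl on a carbonyl carbon. Within the data shown here, one measured step bears on this change, running the other way: an at least 3.3-fold lower number from compound 2 to compound 3 (0.51 log units; beyond the scatter). Compound 4 reintroduces the ring nitrogen that compound 2 carried while retaining the chlorine of compound 3, so a rise in number is expected from compound 3 to compound 4, of about a 2.0-fold higher number from compound 3 to compound 4 (0.30 log units; within the scatter), with a fair chance that only a limit is returned. Compound 4 is estimated at 60000 nM, within 20000 nM to 120000 nM.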

Compound 4, half-maximal inhibitory concentration: > 100000 nM
Compound 4: a limit, no number (the forecaster's own chance of this, stated with the estimate: 45%); middle value at least 1.6-fold (0.22 log units) away from the limit.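

In this assay, 2-chloropyridin-3-yl in place of 3-chlorophenyl on the carbonyl carbon gives an at least 3.3-fold higher number from compound 3 to compound 4 (0.51 log units; beyond the scatter), so keeping a chlorine on the ring does not preserve a readable value in compound 4. The steps from compound 1 and compound 2 to compound 4 cannot be read, as both ends are limits. Among the groups shown, only 3-chlorophenyl gives a number, and the series now stands as follows: the limit of > 100000 nM in this assay, at which 3 of the 4 values shown sit.

Compound 4 differs from compound 3 both in the ring nitrogen and in where the chlorine sits, and the step does not separate the two. On these data alone, whether 2-chlorophenyl or 3-bromophenyl on the carbonyl carbon would return a number remains open.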